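A Chloro Core Gains a Methyl on Its Branched Chain

The compounds below may be only part of what the source reports. "The series", "measured", "known", "first", "only" and "open" are said of these compounds alone.

Compound 2 `CC(C)C(C)NC1=NS(=O)(=O)c2cc(Cl)cnc2N1` and compound 1 `CC(NC1=NS(=O)(=O)c2cccnc2N1)C(C)(C)C` share the same core with different side chains. In a functional assay (ileum) for inhibition, with Cavia porcellus as the target (on this read-out lower numbers stand for an effect already at smaller amounts and higher numbers for an effect only at larger amounts of compound), compound 2 reaches only the limit > 300 uM. Compound 1 likewise sits at the limit > 300 uM in this assay. Both values therefore rest on (the limit of > 300 uM in this assay, at which 2 of the 2 values shown sit). Compound 3 `CC(NC1=NS(=O)(=O)c2cc(Cl)cnc2N1)C(C)(C)C` carries methyl in place of hydrogen on a saturated chain carbon bound to three saturated chain carbons, the change that reads isopropyl to tert-butyl. Since both measured compounds stop at the limit, the step that the limit leaves unreadable from compound 2 to compound 3 is expected to bring no effect beyond the scatter. Compound 3 is estimated at 500 uM, within 100 uM to 3000 uM.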

Compound 3, concentration for half-maximal effect: > 300 uM
Compound 3: only a limit was reported; the forecaster's own chance of this, stated with the estimate: 85%; the middle value does not contradict the limit.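

Compound 3 also ends at a limit, so its steps from compound 1 and compound 2 cannot be read: the limit of > 300 uM in this assay, at which 3 of the 3 values shown sit. As far as these compounds go, whether the methyl or the chloro change alters the effect in this assay stays open.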